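The source may hold more compounds than are shown below. What is called first, only, known or untested is meant among the compounds shown, and "the series" means these compounds.

Compound 2, `COc1nc2sc(C)cn2c1/C=C1/C(=O)Nc2ccccc21`, was examined in a functional assay on cells (Breast carcinoma cell, Homo sapiens) for cytotoxicity, read by sulforhodamine B assay, with a stated time of 48 h (a lower number here means a stronger inhibitor of growth, a higher number a weaker inhibitor of growth), where compound 2 gives 67300 nM. Going by the values given here, the only other compound with a number in this assay is compound 1, `COc1ccc2c(c1)/C(=C/c1c(-c3ccncc3)nc3sccn13)C(=O)N2C`, which in this assay gives 80100 nM. The two numbers lie within the scatter of repeated measurements of each other, so compound 2 can be set neither apart from nor in order with compound 1; both are weak inhibitors of growth, and nothing else is known about either of them here.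

Compound 3, `COc1ccc2c(c1)/C(=C\c1c(OC)nc3sc(C)cn13)C(=O)N2`, has not yet been measured in this assay. It differs from compound 2 in one place: methoxy in place of hydrogen on an aromatic carbon. The methoxy enters on an aromatic carbon of a six-membered aromatic ring of carbon only, within a fused system of two rings, meta to one fused ring and para to another.

Among the compounds with values here, no step between measured compounds in this assay matches this change, so there is nothing to rest a direction on beyond the two weak numbers at hand. The expected step from compound 2 to compound 3 is therefore a 1.1-fold lower number from compound 2 to compound 3 (0.05 log units; within the scatter), that is, none beyond the scatter. Compound 3 is expected to give about 60000 nM, with a range from 25000 nM to 150000 nM.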

Compound 3, concentration for total growth inhibition: 61300 nM
Beside the measured number, compound 3's estimate is 1.0-fold (0.01 log units) below it; the range from low to high includes it.
By their numbers in this assay, from the lowest: compounds 3, 2 and 1 (each within the scatter of the next).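

Going by these compounds alone, the step of a 1.1-fold lower number from compound 2 to compound 3 (0.04 log units; within the scatter) in this assay is the first that can be read between two measured compounds differing in one place, and it lies within the scatter. At this position on the six-membered aromatic ring of carbon only, meta to a fused ring and para to a fused ring, methoxy and hydrogen therefore cannot be told apart by this read-out, and compound 2 and compound 3 both remain weak inhibitors of growth. Nothing given here accounts for this result.

The compounds shown leave open whether another group at this same place, such as an amine, a carboxylic acid or a longer alkoxy chain, would give a step beyond the scatter. Within the data shown here, they also leave open whether methoxy would give a similarly small step on a different core, such as that of compound 1, since this single pair offers the only view of the change and says nothing about how it would read where the rest of the molecule differs.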